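Ring Size in the Carbamate of a Hydroxamate Core

The compounds below may be only part of what the source reports. "The series", "measured", "known", "first", "only" and "open" are said of these compounds alone.

Compounds measured so far:
- compound 1 `O=C(NO)[C@H]1C[C@H](OC(=O)N2CCCC2)CN[C@@H]1C(=O)N1CCC(c2ccccc2)CC1`: in an assay on isolated protein for inhibition of matrix metalloproteinase-9 (Homo sapiens) (a higher number here means a weaker inhibitor, a lower number a stronger inhibitor), compound 1 sits at the limit > 5000 nM, a limit of the assay (the limit of > 5000 nM in this assay, at which 1 of the 2 values shown sits).
- compound 2 `CN1C[C@@H](OC(=O)N2CCCCC2)C[C@H](C(=O)NO)[C@H]1C(=O)N1CCN(c2ccccc2)CC1`: in this assay compound 2 gives 5000 nM.

Among the compounds with values here, compound 2 thus holds the only real number in this assay; the other entry is a limit. Compound 3 `CN1C[C@@H](OC(=O)N2CCCCCC2)C[C@H](C(=O)NO)[C@H]1C(=O)N1CCN(c2ccccc2)CC1` differs from compound 2 in one place: azepan-1-yl in place of piperidin-1-yl on a carbonyl carbon. Within the data shown here, with no measured step of this kind to draw on, the step of no change at the digits printed from compound 2 to compound 3 (within the scatter) is expected to stay within the usual scatter, in no particular direction. Compound 3 is therefore estimated at 5000 nM, between 1500 nM and 15000 nM.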

Compound 3, half-maximal inhibitory concentration: 5000 nM
Beside the measured number, compound 3's estimate shows no gap at the digits printed, and the stated range covers the measured number.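

In this assay, putting azepan-1-yl in place of piperidin-1-yl on the carbonyl carbon gives no change at the digits printed from compound 2 to compound 3 (within the scatter). Within the data shown here, this is the first measured step at this place, and the two rings cannot be told apart here. Compound 1 differs from both in more than one place, and its entry is a limit of the assay, not a number: the limit of > 5000 nM in this assay, at which 1 of the 3 values shown sits.

On these data alone, whether a morpholin-4-yl ring or an open-chain dimethylamino group on that carbonyl carbon would read differently remains open. So does whether the same ring swap would give the same result on another core.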